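Replacing the propargyl ester alcohol with a pyridylmethyl group

This account rests on a few compounds, and the source may have more. Where it says the series, first, only, none or still open, it means among the compounds named here.

Measured so far in an assay on HL-60 cells for agonist activity at vitamin D3 receptor (Homo sapiens), read by microscopy, with a stated time of 96 h; on this read-out higher numbers stand for an effect only at larger amounts of compound and lower numbers for an effect already at smaller amounts:
compound 1 `CCn1c(C(=O)NCC(OC)OC)ccc1C(CC)(CC)c1ccc(OCC(O)C(C)(C)C)c(C)c1`, where compound 1 gives 150 nM;
compound 2 `CCn1c(C(=O)NCCN)ccc1C(CC)(CC)c1ccc(OCC(O)C(C)(C)C)c(C)c1`, where compound 2 gives 10 nM;
compound 3 `C#CC(C)OC(=O)c1ccc(C(CC)(CC)c2ccc(OCC(O)C(C)(C)C)c(C)c2)n1CC`, where compound 3 gives 200 nM.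

Compound 3 holds the highest number of the three: against compound 1 the step is a 1.3-fold higher number from compound 1 to compound 3 (0.12 log units; within the scatter), against compound 2 it is a 20-fold higher number from compound 2 to compound 3 (1.30 log units; beyond the scatter). Compound 4 `CCn1c(C(=O)OCc2ccccn2)ccc1C(CC)(CC)c1ccc(OCC(O)C(C)(C)C)c(C)c1` keeps the ester oxygen and alters only the group on it: (pyridin-2-yl)methyl in place of 1-methylprop-2-yn-1-yl on an oxygen next to a carbonyl group. Among the compounds with values here, no measured step changes this part alone. The steps on the carbonyl substituent show that an amide without a basic amine sat within scatter of the ester, whereas only the aminoethyl amide gave a large move, a 15-fold lower number from compound 1 to compound 2 (1.18 log units; beyond the scatter). A neutral ester change is therefore expected to stay near compound 3. For compound 4 the expected step is no change at the digits printed from compound 3 to compound 4 (within the scatter). The estimate for compound 4 is 200 nM, between 70 nM and 600 nM.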

Compound 4, half-maximal effective concentration: > 50000 nM
Compound 4 gave a limit, no number; the forecaster's own chance of this, stated with the estimate: 5%; at least 250-fold (2.39 log units) between middle value and limit.
By their numbers in this assay, from the lowest: compound 2; then compounds 1 and 3 (each within the scatter of the next). At a limit, above all of these: compound 4.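

In this assay compound 4 gives > 50000 nM, which is a limit of the assay and not a number. The group on the ester oxygen is therefore not a free choice: (pyridin-2-yl)methyl in place of 1-methylprop-2-yn-1-yl gives an at least 250-fold higher number from compound 3 to compound 4 (2.39 log units; beyond the scatter). The ester link alone does not set the read-out, since compound 3 keeps it, and the steps from the amides are an at least 5000-fold higher number from compound 2 to compound 4 (3.69 log units; beyond the scatter) and an at least 330-fold higher number from compound 1 to compound 4 (2.52 log units; beyond the scatter).

Open, from the compounds shown here alone, is whether the aromatic ring or its nitrogen accounts for the step. A benzyl group on the same oxygen would separate the two.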